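This account rests on a few compounds, and the source may have more. Where it says the series, first, only, none or still open, it means among the compounds named here.

Measured so far:
compound 1, `COCC(=O)Nc1c(C(O)(C(F)(F)F)C(F)(F)F)ccc2ccccc12`: 93%
compound 2, `O=C(Nc1c(C(O)(C(F)(F)F)C(F)(F)F)ccc2ccccc12)c1ccc(Cl)cc1`: 99%

Both compounds were tested in a functional assay (Sus scrofa) with sulfonylurea receptors; K-ATP channels (Homo sapiens) as the target; a higher number here means a larger maximal response, a lower number a smaller maximal response. Compound 2 gives 99%. Compound 1 gives 93%. Among the measured compounds shown here, the only measured step, a number 6 percentage points higher from compound 1 to compound 2 (within the scatter), lies within the usual scatter, so the two numbers cannot be told apart, and compound 2 simply shares the top of a two-membered set.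

The next compound, compound 3, is `O=C(Nc1c(C(O)(C(F)(F)F)C(F)(F)F)ccc2ccccc12)c1cccnc1`. It differs from compound 2 in one place: pyridin-3-yl in place of 4-chlorophenyl on a carbonyl carbon. For the measured compounds named here, the one step that bears on this exchange, a number 6 percentage points higher from compound 1 to compound 2 (within the scatter), swapped a group at the same carbonyl carbon and moved the response by less than the scatter. On that basis, in this assay compound 3 is expected to reach 95%, with a range from 80% to 105%. The expected step of a number 4 percentage points lower from compound 2 to compound 3 (within the scatter) stays within the scatter, with no clear direction.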

Compound 3, largest response reached (reported as efficacy), in percent of the reference or control that the assay uses: 97%
Compound 3: middle estimate off by 2 percentage points, on the low side; low and high end bracket the measured number.
By their numbers in this assay, from the lowest: compounds 1, 3 and 2 (each within the scatter of the next).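

Swapping 4-chlorophenyl for pyridin-3-yl on this carbonyl carbon adds a hydrogen-bond acceptor and removes the chlorine, yet it gives a number 2 percentage points lower from compound 2 to compound 3 (within the scatter) in this assay and so shows no measurable change. Replacing methoxymethyl with pyridin-3-yl gives a number 4 percentage points higher from compound 1 to compound 3 (within the scatter) as its step, so methoxymethyl, 4-chlorophenyl and pyridin-3-yl cannot be told apart in this assay, although they differ in their atoms and in whether they contain a ring. No measurement available here explains this lack of change. As far as these compounds go, it remains open whether a different kind of group on this carbonyl carbon, such as an amine or a longer chain ending in a carboxylic acid, would move the response beyond the scatter. Changes elsewhere on the shared core also remain open.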